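A few compounds are considered here, and "the series" means these few. Any claim that something is new, unique, unknown or untested is made for them only; others in the source may bear on it.

Measured compounds:
Compound 1 `CO[C@@H]1CC=C2NN(c3ccc(C)cc3)C(=O)CC[C@]2(c2ccccc2)O1` gives 3170 nM in a functional assay on A549 cells (Homo sapiens) for cytotoxicity, read by sulforhodamine B assay, with a stated time of 48 h; on this read-out higher numbers stand for weaker inhibition and lower numbers for stronger inhibition.
Compound 2 `COc1cc(OC)cc(N2NC3=CC[C@@H](OC)O[C@@]3(c3ccccc3)CCC2=O)c1` gives 2900 nM in this assay.
Compound 3 `CO[C@@H]1CC=C2N(c3ccc(C)cc3)C(=O)C[C@]2(c2ccccc2)O1` gives 3920 nM in this assay.

Compound 3 has the highest number of the three, but its gaps to compound 1 and compound 2 both fall within the usual scatter, so all three compounds behave alike in this assay. Compound 4 `CO[C@@H]1CC=C2N(c3c[nH]c4ccccc34)C(=O)C[C@]2(c2ccccc2)O1` has not yet been measured. It differs from compound 3 in one place: 1H-indol-3-yl in place of 4-methylphenyl on an amide-type nitrogen in a ring.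

Within the data shown here, one measured step touches the same position. There, a 1.1-fold lower number from compound 1 to compound 2 (0.04 log units; within the scatter), so exchanging one aromatic group for another on that nitrogen left the number essentially where it was. Among the measured compounds shown here, that step swapped one six-membered carbon ring for another, whereas compound 4 brings in a fused two-ring group with a hydrogen-bond donor; no measured pair shows such a change. For the measured compounds named here, with only the step from compound 1 to compound 2 as a guide, compound 4 is expected to stay close to compound 3, giving a 1.1-fold lower number from compound 3 to compound 4 (0.05 log units; within the scatter). Compound 4 is therefore estimated at 3500 nM in this assay, with a likely range from 1200 nM to 10000 nM.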

Compound 4, half-maximal inhibitory concentration: 5200 nM
Compound 4: the middle estimate sits 1.5-fold (0.17 log units) below what was measured; measured number inside the range.
By their numbers in this assay, from the lowest: compounds 2, 1, 3 and 4 (each within the scatter of the next).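

In this assay, putting 1H-indol-3-yl on the amide-type nitrogen in place of 4-methylphenyl gives a 1.3-fold higher number from compound 3 to compound 4 (0.12 log units; within the scatter), so the number does not clearly move. The earlier step at this nitrogen only exchanged one six-membered carbon ring for another on a different core, whereas this one shows that a fused two-ring group carrying a hydrogen-bond donor also leaves the number within the scatter, here on the core of compound 3. No supporting measurement is available to explain this result.

On these data alone, all four compounds carry an aromatic ring system on this nitrogen, so it remains open whether a simple ethyl or longer alkyl chain would behave the same way. As far as these compounds go, it is also open whether a phenyl ring bearing a carboxylic acid or an amine would shift the number beyond the scatter.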